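This account rests on a few compounds, and the source may have more. Where it says the series, first, only, none or still open, it means among the compounds named here.

Measured so far in a functional assay on U-937 cells (Homo sapiens) for cytotoxicity, read by MTT assay, with a stated time of 24 h; on this read-out lower numbers stand for stronger inhibition and higher numbers for weaker inhibition:
compound 1 `CC(=O)Oc1c(Br)cc(Br)cc1Oc1ccc(Br)cc1Br` gives 32.3 ug/mL
compound 2 `COc1ccccc1N1CCN(CCCCCOc2c(Br)cc(Br)cc2Oc2ccc(Br)cc2Br)CC1` gives 37.5 ug/mL
compound 3 `CC(C)(C)OC(=O)N1CCN(CCCCCOc2c(Br)cc(Br)cc2Oc2ccc(Br)cc2Br)CC1` gives 35.5 ug/mL

Compound 1 has no distinct rank in this set. Its value lies within the usual scatter of those of compound 2 and compound 3, so these numbers cannot tell the three apart.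

Compound 4 `C=CCOc1c(Br)cc(Br)cc1Oc1ccc(Br)cc1Br` has not yet been measured. It differs from compound 1 in one place, with allyl in place of acetyl on an oxygen on an aromatic ring.

For the measured compounds named here, the one measured step, a 1.1-fold lower number from compound 2 to compound 3 (0.02 log units; within the scatter), also stays within the scatter, but it concerns an amine nitrogen in a ring, so it bears on this change only indirectly. More relevant is that compound 2 and compound 3 carry much larger groups than acetyl on that same oxygen. Even so, compound 2 at 37.5 ug/mL and compound 3 at 35.5 ug/mL remain within the scatter of compound 1 at 32.3 ug/mL. Going by the values given here, no measured compound carries allyl, so this is only modest support, and no step beyond the scatter is expected in this assay.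

The expected change is small: a 1.0-fold higher number from compound 1 to compound 4 (0.01 log units; within the scatter).

For compound 4 the estimated value is 33 ug/mL, with an expected range from 20 ug/mL to 52 ug/mL.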

Compound 4, half-maximal inhibitory concentration: 29 ug/mL
Beside the measured number, compound 4's estimate is 1.1-fold (0.06 log units) above it; low and high end bracket the measured number.
By their numbers in this assay, from the lowest: compounds 4, 1, 3 and 2 (each within the scatter of the next).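

In this assay, the direct exchange of acetyl for allyl on an oxygen on an aromatic ring gives a 1.1-fold lower number from compound 1 to compound 4 (0.05 log units; within the scatter). This single change replaces the acetoxy group with allyloxy while keeping the same number of heavy atoms: acetyl brings a hydrogen-bond acceptor and allyl brings none, yet the read-out does not separate the two compounds, so at this position the acceptor in acetyl shows no measurable role in this cell assay. No measurement at hand explains this outcome.

Still open, going by these compounds, is whether a group of a different kind on this oxygen, such as a free hydroxyl, a short chain ending in a carboxylic acid, or a simple primary amine on a chain, would move the number beyond the scatter. With all four compounds ranked so that each value lies within the scatter of the next, the compounds shown do not yet reveal any group at this oxygen that changes the read-out, so how much this position matters remains undecided.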